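The compounds below may be only part of what the source reports. "The series", "measured", "known", "first", "only" and "open" are said of these compounds alone.

Values so far in a functional assay on HOS cells (Homo sapiens) for antiproliferative activity, read by sulforhodamine B assay (on this read-out higher numbers stand for weaker inhibition of growth and lower numbers for stronger inhibition of growth), are as follows:

- compound 1 `CC(=O)O[C@@H]1[C@@H](OCc2ccccc2)[C@H](OCc2ccccc2)[C@@H](COCc2ccccc2)O[C@H]1C` gives 8800 nM as a number
- compound 2 `CC[C@@H]1O[C@H](COCc2ccccc2)[C@@H](OCc2ccccc2)[C@H](OCc2ccccc2)[C@H]1O` gives 34200 nM as a number
- compound 3 `CC[C@H]1O[C@H](COCc2ccccc2)[C@@H](OCc2ccccc2)[C@H](OCc2ccccc2)[C@H]1O` gives > 50000 nM as a limit of the assay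

Of the two true numbers, compound 2 stands higher, with compound 1 lower and the gap beyond the scatter. Compound 4 `CC[C@@H]1O[C@H](COCc2ccccc2)[C@@H](OCc2ccccc2)[C@H](OCc2ccccc2)[C@H]1OC(C)=O` follows from compound 2 by acetyl in place of hydrogen on an oxygen on a saturated carbon and so turns hydroxy to acetoxy, with acetyl in place of hydrogen on an oxygen on a saturated carbon.

Within the data shown here, the one measured step of an at least 1.4-fold higher number from compound 2 to compound 3 (0.16 log units; that floor lies within the scatter) is bounded by the limit of > 50000 nM in this assay, at which 1 of the 3 values shown sits, and concerns only the fact that compounds 2 and 3 differ only in the configuration as drawn so it gives no size for this change. Among the measured compounds shown here, compound 1 also carries acetoxy and gives 8800 nM in this assay but no measured step ties it to compound 2, so it is only a weak guide. A modest move to a lower number is therefore expected, with a 2.3-fold lower number from compound 2 to compound 4 (0.36 log units; beyond the scatter) as the estimated step and a wide margin. Compound 4 is estimated at 15000 nM with an expected range from 5000 nM to 45000 nM in this assay.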

Compound 4, concentration for 50% growth inhibition: > 50000 nM
Compound 4 gave a limit, no number (the forecaster's own chance of this, stated with the estimate: 12%); at least 3.3-fold (0.52 log units) between middle value and limit.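

In this assay compound 4 gives > 50000 nM, which is a limit of the assay and not a number. Acetoxy in place of hydroxy on this ring position therefore brings no lower number, and the step, an at least 1.4-fold higher number from compound 2 to compound 4 (0.16 log units; that floor lies within the scatter), has only a floor and no size, with its upper end hidden by the assay's ceiling: the limit of > 50000 nM in this assay, at which 2 of the 4 values shown sit. With acetoxy present in both compounds, the chain change is the clearer result, since an at least 5.6-fold higher number from compound 1 to compound 4 (0.75 log units; beyond the scatter) shows that carrying acetoxy does not by itself give a value like that of compound 1.

On these data alone, what a methyl or a benzoyl in place of the acetyl on this oxygen would give remains open. Also open, as far as these compounds go, is whether the chain change holds with a free hydroxy, and how an acetoxy form of compound 3 would read.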